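From 4-methoxyphenyl to 3,4-dimethylphenyl on an amide-type nitrogen

The compounds below may be only part of what the source reports. "The series", "measured", "known", "first", "only" and "open" are said of these compounds alone.

Of the compounds shown here, two have numbers so far in a functional assay on L1210 cells (Mus musculus) for cytotoxicity (a lower number here means a stronger inhibitor, a higher number a weaker inhibitor), and they set the frame for this note. Compound 1 (`COc1ccc(NC(=O)/C=C/C(=O)N2C/C(=C\c3ccc([N+](=O)[O-])cc3)C(=O)/C(=C/c3ccc([N+](=O)[O-])cc3)C2)cc1`) gives 2900 nM and compound 2 (`CC(=O)c1ccc(NC(=O)/C=C/C(=O)N2C/C(=C\c3ccccc3)C(=O)/C(=C/c3ccccc3)C2)cc1`) gives 5500 nM in that test. Among the compounds with values here, these two values lie within the scatter of each other, so compound 1 cannot be separated from the only other number available. Within the data shown here, no measured pair differs in one place only, which leaves no step to serve as a guide.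

Compound 3 (`Cc1ccc(NC(=O)/C=C/C(=O)N2C/C(=C\c3ccc([N+](=O)[O-])cc3)C(=O)/C(=C/c3ccc([N+](=O)[O-])cc3)C2)cc1C`) keeps the core of compound 1 and carries 3,4-dimethylphenyl in place of 4-methoxyphenyl on an amide-type nitrogen. Among the measured compounds shown here, no measurement yet shows what this change does in this assay and no shift beyond the scatter is expected, in either direction. The expected step of a 1.0-fold higher number from compound 1 to compound 3 (0.01 log units; within the scatter) is therefore small, and the expectation is anchored on compound 1 at 2900 nM as the closest structure. Compound 3 is estimated at 3000 nM (expected range 1100 nM to 8000 nM).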

Compound 3, half-maximal inhibitory concentration: 4900 nM
The estimate for compound 3 lay 1.6-fold (0.21 log units) below the measured number; low and high end bracket the measured number.
By their numbers in this assay, from the lowest: compounds 1, 3 and 2 (each within the scatter of the next).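

With the core of compound 1 held fixed, the series now has a step that changes one place only: 3,4-dimethylphenyl in place of 4-methoxyphenyl on an amide-type nitrogen gives a 1.7-fold higher number from compound 1 to compound 3 (0.23 log units; within the scatter) in this assay for this pair. At this position, an aryl group carrying an oxygen and an all-carbon aryl group with the same heavy-atom count therefore cannot be told apart in this read-out, even though the hydrogen-bond acceptor of 4-methoxyphenyl leaves with the change. No measured property or other outside information bears on this result.

Going by these compounds, whether this position stays as undemanding with a different kind of group, such as an amine, a carboxylic acid or a longer alkyl chain in place of 3,4-dimethylphenyl, remains open, as the two groups compared here are both substituted phenyl groups. On these data alone, compound 2 differs from compound 1 and from compound 3 in more than one place, so what the rest of the shared core contributes also stays open.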